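Working notes: bromo in place of cyano

The source may hold more compounds than are shown below. What is called first, only, known or untested is meant among the compounds shown, and "the series" means these compounds.

Among the compounds with values here, in a physicochemical assay for lipophilicity (a lower number here means a more polar compound, a higher number a more lipophilic compound), compound 2 (`N#Cc1ccc(OCC2CCN(CCCF)CC2)cc1`) gives 2.93, the lower of the two numbers so far. Compound 1 (`Brc1ccc(OCC2CCN(CC3CC3)CC2)cc1`) gives 6.22, and the gap to compound 2 lies beyond the scatter. Compound 3 (`FCCCN1CCC(COc2ccc(Br)cc2)CC1`) departs from compound 2 by a single change, bromo in place of cyano on an aromatic carbon. Within the data shown here, no measured step between compounds differing in one place is available as a guide. Compound 1 also carries bromo and reads 6.22, which leaves room upward. An upward step a number 1.47 log units higher from compound 2 to compound 3 (beyond the scatter) is expected, beyond the scatter in this assay. Compound 3 is estimated at 4.4, with an expected range of 3.7 to 5.3.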

Compound 3, partition coefficient: 5.88
Compound 3: the middle estimate sits 1.48 log units below what was measured; measured number above the stated range.
By their numbers in this assay, from the lowest: compound 2; then compound 3; then compound 1.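

In this assay, within the data shown here, bromo in place of cyano on an aromatic carbon gives a large rise, a number 2.95 log units higher from compound 2 to compound 3 (beyond the scatter), the first single-place reading at this position. The other single-place change, 2-fluoroethyl in place of cyclopropyl on a saturated chain carbon bound to an amine nitrogen in a ring, is modest beside it, a number 0.34 log units lower from compound 1 to compound 3 (beyond the scatter). Nothing available accounts for the size of either step.

Open, on these data alone, is where chloro, methoxy or a carboxylic acid on the same aromatic carbon would fall relative to cyano and bromo. Also open, as far as these compounds go, is whether the bromo-for-cyano step keeps its size with cyclopropyl in the other place.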